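Rat microsomal clearance across the aryl/alkynyl replacement series

The compounds below may be only part of what the source reports. "The series", "measured", "known", "first", "only" and "open" are said of these compounds alone.

Measured compounds:
- compound 1 `Nc1ccc(S(=O)(=O)N2CCN(c3ncc(C(O)(C(F)(F)F)C(F)(F)F)cc3C#CCO)CC2)cn1`: 65 mL.min-1.g-1
- compound 2 `CC(C)n1cc(-c2cc(C(O)(C(F)(F)F)C(F)(F)F)cnc2N2CCN(S(=O)(=O)c3ccc(N)nc3)CC2)cn1`: 198 mL.min-1.g-1
- compound 3 `Cc1ccc(-c2cc(C(O)(C(F)(F)F)C(F)(F)F)cnc2N2CCN(S(=O)(=O)c3ccc(N)nc3)CC2)cn1`: 182 mL.min-1.g-1

In an ADME assay (liver) for metabolic stability, with Liver microsome (Rattus norvegicus) as the target, using microsomes and NADPH, with a stated time of 30 min, tested at 1 uM (on this read-out higher numbers stand for fast clearance and lower numbers for slow clearance), compound 1 gives 65 mL.min-1.g-1, the lowest of the three numbers. Compound 2 and compound 3 both sit higher: a 3.0-fold higher number from compound 1 to compound 2 (0.48 log units; beyond the scatter) and a 2.8-fold higher number from compound 1 to compound 3 (0.45 log units; beyond the scatter), each beyond the scatter, while a 1.1-fold lower number from compound 2 to compound 3 (0.04 log units; within the scatter) is within the scatter.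

Compound 4 `Nc1ccc(S(=O)(=O)N2CCN(c3ncc(C(O)(C(F)(F)F)C(F)(F)F)cc3-c3ccc4scnc4c3)CC2)cn1` is not yet measured in this assay. It differs from compound 1 as follows: 1,3-benzothiazol-5-yl in place of 3-hydroxyprop-1-yn-1-yl on an aromatic carbon. Both measured steps from compound 1 bear on this change, since each replaces the 3-hydroxyprop-1-yn-1-yl group with a ring-containing group on the same aromatic carbon, and both gave a modest rise. The 1,3-benzothiazol-5-yl group contains two fused aromatic rings, which the measured steps do not cover, so the size is uncertain, but a step of similar direction is expected. Compound 4 is therefore estimated to give 210 mL.min-1.g-1 (range 110 mL.min-1.g-1 to 420 mL.min-1.g-1), an expected step of a 3.2-fold higher number from compound 1 to compound 4 (0.51 log units; beyond the scatter).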

Compound 4, intrinsic clearance in microsomes: 147 mL.min-1.g-1
Estimate against measurement, compound 4: 1.4-fold (0.15 log units) above, within the range that was stated.
By their numbers in this assay, from the lowest: compound 1; then compounds 4, 3 and 2 (each within the scatter of the next).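

Working notes: in this assay, the 1,3-benzothiazol-5-yl group, with its fused pair of aromatic rings, still leaves the number clearly up on the 3-hydroxyprop-1-yn-1-yl group, as a 2.3-fold higher number from compound 1 to compound 4 (0.35 log units; beyond the scatter) shows. This position does not separate the three ring-bearing groups, with a 1.2-fold lower number from compound 3 to compound 4 (0.09 log units; within the scatter) and a 1.3-fold lower number from compound 2 to compound 4 (0.13 log units; within the scatter), so in compounds 2, 3 and 4 the larger entering group makes no readable difference, and none of the three goes against this. Nothing measured here explains these steps.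

Still open, on these data alone, is which part of the 3-hydroxyprop-1-yn-1-yl group, the triple bond or the hydroxyl, goes with the lower number of compound 1. Also open, as far as these compounds go, is how an amine, a carboxylic acid or a longer chain on this aromatic carbon would read.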